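A few compounds are considered here, and "the series" means these few. Any claim that something is new, unique, unknown or untested is made for them only; others in the source may bear on it.

Measured so far:
compound 1 `Cn1nc2c(=O)n(CC3(O)CCN(Cc4ccc(-c5ccco5)cc4Cl)CC3)cnc2c1-c1ccc(CO)cc1` — 42.5 nM
compound 2 `Cn1nc2c(=O)n(CC3(O)CCN(Cc4ccc(-c5ccco5)cc4Cl)CC3)cnc2c1-c1ccc(C2(N)CC2)cc1` — 66.1 nM
compound 3 `Cn1nc2c(=O)n(CC3(O)CCN(Cc4ccc(-c5ccco5)cc4Cl)CC3)cnc2c1-c1ccc(C(N)=O)cc1` — 80.8 nM

In an assay on isolated protein for inhibition of ubiquitin carboxyl-terminal hydrolase 7 (Homo sapiens), with stated times of 30 min and 2 h (on this read-out lower numbers stand for stronger inhibition and higher numbers for weaker inhibition), compound 3 shows the highest of the three numbers, but its gaps to the others, a 1.2-fold higher number from compound 2 to compound 3 (0.09 log units; within the scatter) and a 1.9-fold higher number from compound 1 to compound 3 (0.28 log units; within the scatter), both sit within the scatter. Compound 4 `Cn1nc2c(=O)n(CC3(O)CCN(Cc4ccc(-c5ccco5)cc4Cl)CC3)cnc2c1-c1ccc(OC(F)F)cc1` differs from compound 3 by difluoromethoxy in place of carbamoyl on an aromatic carbon. Among the measured compounds shown here, no measured pair places difluoromethoxy at this aromatic carbon; the three changes there, a 1.6-fold higher number from compound 1 to compound 2 (0.19 log units; within the scatter), a 1.9-fold higher number from compound 1 to compound 3 (0.28 log units; within the scatter) and a 1.2-fold higher number from compound 2 to compound 3 (0.09 log units; within the scatter), all stay within the scatter, so in this assay no step beyond the scatter is expected for compound 4 either. The value of compound 4 is estimated at 60 nM, range 28 nM to 130 nM, which means an expected 1.3-fold lower number from compound 3 to compound 4 (0.13 log units; within the scatter).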

Compound 4, half-maximal inhibitory concentration: 179 nM
Compound 4: middle estimate off by 3.0-fold (0.47 log units), on the low side; measured number outside the range, above it.
By their numbers in this assay, from the lowest: compounds 1, 2 and 3 (each within the scatter of the next); then compound 4.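

Among the compounds shown here, at this position, on an aromatic carbon para to a large group, difluoromethoxy gives the first steps beyond the scatter in this assay: a 2.2-fold higher number from compound 3 to compound 4 (0.35 log units; beyond the scatter), a 2.7-fold higher number from compound 2 to compound 4 (0.43 log units; beyond the scatter) and a 4.2-fold higher number from compound 1 to compound 4 (0.62 log units; beyond the scatter). The position therefore does not tolerate every group equally, although hydroxymethyl, 1-aminocyclopropyl and carbamoyl remain within the scatter of one another. No available measurement bears on the cause of these steps.

The compounds shown leave open whether the fluorine atoms or the oxygen link go with the weaker inhibition. Methoxy, trifluoromethyl and a carboxylic acid at this carbon would help separate these possibilities.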